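Switching the sulfonyl aryl from chlorophenyl to tolyl

A few compounds are considered here, and "the series" means these few. Any claim that something is new, unique, unknown or untested is made for them only; others in the source may bear on it.

Measured compounds:
compound 1 `O=C(Nc1cccc(/C=C/C(=O)c2nc3ccccc3[nH]2)c1)c1cccc(Cl)c1` gives 7840 nM
compound 2 `Cc1cc(C)cc(C(=O)Nc2cccc(/C=C/C(=O)c3nc4ccccc4[nH]3)c2)c1` gives 24600 nM
compound 3 `O=C(/C=C/c1cccc(NS(=O)(=O)c2cccc(Cl)c2)c1)c1nc2ccccc2[nH]1` gives 4160 nM

In a functional assay on MCF7 cells (Homo sapiens) for antiproliferative activity, read by MTT assay, with a stated time of 48 h (a higher number here means a weaker inhibitor, a lower number a stronger inhibitor), compound 3 carries the lowest of the three numbers. Its separation from compound 1 is small, a 1.9-fold lower number from compound 1 to compound 3 (0.28 log units; within the scatter) being within the scatter, whereas a 5.9-fold lower number from compound 2 to compound 3 (0.77 log units; beyond the scatter) lies beyond it. Compound 4 `Cc1ccc(S(=O)(=O)Nc2cccc(/C=C/C(=O)c3nc4ccccc4[nH]3)c2)cc1` differs from compound 3 in one place: 4-methylphenyl in place of 3-chlorophenyl on a sulfonyl sulfur. Among the measured compounds shown here, no measured pair repeats this exact change. The nearest guide is the exchange of a chlorophenyl for a methyl-bearing phenyl on the amide side, which gave a 3.1-fold higher number from compound 1 to compound 2 (0.50 log units; beyond the scatter), a modest weakening. The carbonyl-to-sulfonyl swap itself, a 1.9-fold lower number from compound 1 to compound 3 (0.28 log units; within the scatter), stayed within the scatter. Taking the chlorine-to-methyl step as the better clue, a modest rise in the number for compound 4 is expected, of about a 1.9-fold higher number from compound 3 to compound 4 (0.28 log units; within the scatter). Compound 4 is therefore estimated to give 8000 nM, with a likely range from 3500 nM to 20000 nM.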

Compound 4, half-maximal inhibitory concentration: 3220 nM
For compound 4 the middle estimate is 2.5-fold (0.40 log units) above the measured one, and the stated range ends above it.
By their numbers in this assay, from the lowest: compounds 4, 3 and 1 (each within the scatter of the next, the first and the last beyond it); then compound 2.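

In this assay, putting 4-methylphenyl in place of 3-chlorophenyl on the sulfonyl sulfur gave a 1.3-fold lower number from compound 3 to compound 4 (0.11 log units; within the scatter) and so stays within the scatter, which means that this position takes either ring without a change that can be told apart. The methyl-bearing sulfonyl compound also stands clear of both amides, with a 2.4-fold lower number from compound 1 to compound 4 (0.39 log units; beyond the scatter) and a 7.6-fold lower number from compound 2 to compound 4 (0.88 log units; beyond the scatter) both beyond the scatter, so a methyl-bearing ring here does not bring the weakening seen on the carbonyl side in compound 2. Nothing available explains this tolerance.

The two rings differ in both the group and its place on the ring, so these compounds cannot separate those two effects. As far as these compounds go, how a phenyl ring bearing an amine or a carboxylic acid would fare on the sulfonyl sulfur also remains open.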